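The compounds below may be only part of what the source reports. "The series", "measured", "known", "first", "only" and "open" are said of these compounds alone.

In an assay on cells for antagonist activity at transient receptor potential cation channel subfamily V member 1 (Homo sapiens), read by FLIPR and calcium flux, with a stated time of 6 min (a higher number here means a weaker inhibitor, a lower number a stronger inhibitor), the measured compounds are: compound 1 `CCCCN(C)c1nc(C(C)(C)C)ccc1CNC(=O)C(C)c1ccc(NS(C)(=O)=O)c(F)c1` with 1.2 nM; compound 2 `CC(C(=O)NCc1ccc(C(C)(C)C)nc1N1CCCC1)c1ccc(NS(C)(=O)=O)c(F)c1` with 1.2 nM; compound 3 `CC(C(=O)NCc1ccc(C(C)(C)C)nc1SC1CCCC1)c1ccc(NS(C)(=O)=O)c(F)c1` with 2.5 nM.

Compound 3 holds the highest of the three numbers: a 2.1-fold higher number from compound 1 to compound 3 (0.32 log units; beyond the scatter) and a 2.1-fold higher number from compound 2 to compound 3 (0.32 log units; beyond the scatter), while no change at the digits printed from compound 1 to compound 2 (within the scatter). Compound 4 `CC(C(=O)NCc1ccc(C(C)(C)C)nc1C1CCCCC1)c1ccc(NS(C)(=O)=O)c(F)c1` differs from compound 3 by cyclohexyl in place of cyclopentylsulfanyl on an aromatic carbon. Going by the values given here, no measured step exchanges a sulfur-linked ring for a ring attached directly through carbon, so the two steps into compound 3 bear on it only as a measure of how little this position has moved the numbers so far. Compound 4 is therefore expected in this assay to give about 2.5 nM, within 0.8 nM to 8 nM. The expected step, no change at the digits printed from compound 3 to compound 4 (within the scatter), is estimated to stay within the usual scatter.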

Compound 4, inhibition constant: 3.1 nM
Compound 4: middle estimate off by 1.2-fold (0.09 log units), on the low side; the range from low to high includes it.
By their numbers in this assay, from the lowest: compounds 1 and 2 (each within the scatter of the next); then compounds 3 and 4 (each within the scatter of the next).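

In this assay, removing the sulfur link and attaching cyclohexyl directly through carbon leaves the number within the scatter (a 1.2-fold higher number from compound 3 to compound 4 (0.09 log units; within the scatter)). The position therefore tolerates this change in linking atom for these two rings. Cyclohexyl also gives modestly higher numbers than the two nitrogen-linked groups (a 2.6-fold higher number from compound 2 to compound 4 (0.41 log units; beyond the scatter); a 2.6-fold higher number from compound 1 to compound 4 (0.41 log units; beyond the scatter)), as cyclopentylsulfanyl does. Nothing available here accounts for these steps. The compounds shown leave open how an oxygen-linked ring such as cyclopentyloxy, or an aromatic ring such as phenyl, would fare at this position.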